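Swapping Methoxy for Iodo on a Triazole-Linked Aryl Ring

The source may report more compounds than this note shows. Statements on the series, on what has been measured and on what is new or still open speak of the compounds shown alone.

Measured compounds:
compound 1 `CC1(C)CCC[C@]1(C)c1ccc(C=O)cc1`: 217000 nM
compound 2 `C=C1CCC[C@]2(C)CCC(c3cn(-c4ccc(OC)cc4)nn3)=CC[C@@]12C`: 34700 nM

In a functional assay on A549 cells (Homo sapiens) for cytotoxicity, read by MTT assay, with a stated time of 48 h (a lower number here means a stronger inhibitor, a higher number a weaker inhibitor), compound 1 gives 217000 nM, while compound 2, with a different core, gives 34700 nM. Compound 2 therefore holds the lower of the two numbers, and its gap to compound 1 lies beyond the usual scatter of the assay.

Compound 3 `C=C1CCC[C@]2(C)CCC(c3cn(-c4ccc(I)cc4)nn3)=CC[C@@]12C` is not yet measured. It differs from compound 2 in one place: iodo in place of methoxy on an aromatic carbon. Among the compounds with values here, no measured pair shows this change, so its effect is unknown from the data at hand.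

With nothing to anchor the step, a modest move is expected, if any, and the guess leans slightly toward a lower number, since compound 2 already stands at 34700 nM and the change is confined to a single substituent on the aryl ring. The expected step from compound 2 to compound 3 is a 1.4-fold lower number from compound 2 to compound 3 (0.14 log units; within the scatter), which may well sit within the scatter. For compound 3 in this assay the estimate is 25000 nM, with a range from 8000 nM to 80000 nM.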

Compound 3, half-maximal inhibitory concentration: 137000 nM
Compound 3: the middle estimate sits 5.5-fold (0.74 log units) below what was measured, and the stated range ends below it.
By their numbers in this assay, from the lowest: compound 2; then compounds 3 and 1 (each within the scatter of the next).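

Within the data shown here, this is the first single-place change, and it shows that the substituent on this six-membered aromatic ring is not a silent position in this assay: iodo in place of methoxy gives a 3.9-fold higher number from compound 2 to compound 3 (0.60 log units; beyond the scatter) with the rest of the structure unchanged. Of these two groups on the shared core, 4-methoxyphenyl therefore goes with the lower number and 4-iodophenyl with the higher one, so a change of this one substituent is enough to move the reading by more than repeat measurements would. Nothing available accounts for this step or links it to any property of either group.

With only methoxy and iodo seen at this position, the compounds shown leave open whether the lower number of compound 2 is particular to methoxy or would also be found with a hydroxyl, an amine, a fluoro or a longer alkoxy chain in its place. They also leave open whether the same exchange of iodo for methoxy would shift the number in the same direction on a different core.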